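The compounds below may be only part of what the source reports. "The series", "measured", "known", "first", "only" and "open" are said of these compounds alone.

Measured compounds:
- compound 1 `CCOC(=O)c1cn(Cc2nnc(-c3cc(S(N)(=O)=O)c(SCc4ccccc4)cc3Cl)o2)nn1`: in a functional assay on HCT-116 cells (Homo sapiens) for cytotoxicity, read by MTT assay, with a stated time of 72 h (a higher number here means a weaker inhibitor, a lower number a stronger inhibitor), compound 1 gives 108000 nM
- compound 2 `CC(C)(O)c1cn(Cc2nnc(-c3cc(S(N)(=O)=O)c(SCc4ccccc4)cc3Cl)o2)nn1`: in this assay compound 2 gives 82000 nM
- compound 3 `NS(=O)(=O)c1cc(-c2nnc(Cn3cc(-c4ccccc4)nn3)o2)c(Cl)cc1SCc1ccccc1`: in this assay compound 3 gives 75000 nM

Compound 3 holds the lowest of the three numbers, but its separation from the others is small: a 1.1-fold lower number from compound 2 to compound 3 (0.04 log units; within the scatter) and a 1.4-fold lower number from compound 1 to compound 3 (0.16 log units; within the scatter) both stay within the scatter, as does a 1.3-fold lower number from compound 1 to compound 2 (0.12 log units; within the scatter). Across these three compounds, then, exchanging the group on the aromatic carbon of the shared core has not moved this assay beyond what repeat measurements would show.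

Compound 4 `COc1ccc(-c2cn(Cc3nnc(-c4cc(S(N)(=O)=O)c(SCc5ccccc5)cc4Cl)o3)nn2)cc1` differs from compound 3 by methoxy in place of hydrogen on an aromatic carbon. Going by the values given here, no measured pair touches this exact position, so the bearing steps are only the indirect ones above, all within the scatter. A small decoration on the phenyl is expected to follow the same flat picture, and the step of a 1.1-fold lower number from compound 3 to compound 4 (0.03 log units; within the scatter) is therefore expected to fall within the scatter, with no clear direction. For compound 4 the estimate in this assay is 70000 nM, in a range from 35000 nM to 140000 nM.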

Compound 4, half-maximal inhibitory concentration: 190000 nM
Estimate against measurement, compound 4: 2.7-fold (0.43 log units) below; the whole stated range lies below it.
By their numbers in this assay, from the lowest: compounds 3, 2, 1 and 4 (each within the scatter of the next, the first and the last beyond it).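

In this assay, the phenyl group of compound 3 does not tolerate every small addition, as the earlier flat steps might have suggested: methoxy in place of hydrogen gives a 2.5-fold higher number from compound 3 to compound 4 (0.40 log units; beyond the scatter), a modest step but one beyond the scatter. The 4-methoxyphenyl group also separates from 1-hydroxy-1-methylethyl, with a 2.3-fold higher number from compound 2 to compound 4 (0.36 log units; beyond the scatter), but not from ethoxycarbonyl, with a 1.8-fold higher number from compound 1 to compound 4 (0.25 log units; within the scatter), so this change stands clear of two of the three earlier compounds only. Nothing available on these compounds accounts for the higher number.

From the compounds shown here alone, it remains open whether this step belongs to methoxy itself or would follow any group on that carbon, which a hydroxyl, an amine or a carboxylic acid there could separate. Also open, going by these compounds, is whether a longer alkoxy chain in the same place would extend the step or reverse it.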